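Purine benzamides: ring alkyl replaces branched alkyl on core nitrogen

A few compounds are considered here, and "the series" means these few. Any claim that something is new, unique, unknown or untested is made for them only; others in the source may bear on it.

Measured so far:
compound 1 `CCC(C)n1cnc2c(NCc3ccc(C(=O)Nc4ccccc4N)cc3)nc(Cl)nc21` — 65%
compound 2 `CC1CCN(c2nc(Cl)nc3c2ncn3Cc2ccc(/C=C/C(=O)Nc3ccccc3N)cc2)CC1` — 32.2%

Among the measured compounds shown here, in a functional assay on HepG2 cells (Homo sapiens) for antiproliferative activity, read by CCK-8 assay, with a stated time of 72 h, tested at 8 uM (a lower number here means a weaker effect, a higher number a stronger effect of the compound at the concentration tested), compound 1 gives 65%, the higher of the two numbers; compound 2 gives 32.2%, a gap that lies beyond the scatter, though no single step links the two structures. Compound 3 `Nc1ccccc1NC(=O)c1ccc(CNc2nc(Cl)nc3c2ncn3C2CCCC2)cc1` differs from compound 1 by cyclopentyl in place of sec-butyl on an aromatic nitrogen. For the measured compounds named here, with no measured step of this kind to lean on, the expected change is small, and the step of a number 5 percentage points lower from compound 1 to compound 3 (within the scatter) is estimated to stay within the scatter. For compound 3 the expected value is 60%, with a range from 42% to 78%.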

Compound 3, a percentage reported as inhibition, at one concentration (the size of the read-out at that concentration, not a potency): 74.9%
Compound 3: the middle estimate sits 14.9 percentage points below what was measured; low and high end bracket the measured number.
By their numbers in this assay, from the lowest: compound 2; then compounds 1 and 3 (each within the scatter of the next).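

The step at this position, on an aromatic nitrogen of a five-membered aromatic ring, reads a number 9.9 percentage points higher from compound 1 to compound 3 (within the scatter) in this assay. Cyclopentyl, with its one five-membered non-aromatic ring of carbon only, therefore stands in place of sec-butyl without a change beyond the scatter, so this position accepts a ring as well as a branched chain. No available evidence bears on this result.

Going by these compounds, whether cyclohexyl, a longer chain such as n-hexyl, or a group carrying an amine would hold the read-out at this position stays open. On these data alone, the read-out also reflects one concentration only, so any difference in potency between these compounds remains unknown.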